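Arylthioacetyl piperazine in the melanocortin-4 series

The source may hold more compounds than are shown below. What is called first, only, known or untested is meant among the compounds shown, and "the series" means these compounds.

Compound 2 `CC(C)C[C@H](N)c1cc(C(F)(F)F)ccc1N1CCN(C(=O)CC(C)C(=O)c2ccc(Cl)cc2)CC1` gives the highest number of the two measured compounds in an assay on HEK293 cells for displacement of a labelled ligand from Melanocortin receptor 4 (Homo sapiens) (on this read-out higher numbers stand for weaker inhibition and lower numbers for stronger inhibition), where compound 2 gives 1100 nM. Among the measured compounds shown here, its nearest neighbour is compound 1 `CC(C)C[C@H](N)c1cc(C(F)(F)F)ccc1N1CCN(C(=O)[C@H](C)Cc2ccc(Cl)cc2)CC1`, which in this assay gives 31 nM; the one measured step, a 35-fold higher number from compound 1 to compound 2 (1.55 log units; beyond the scatter), is large and beyond the scatter. Compound 3 `CC(C)C[C@H](N)c1cc(C(F)(F)F)ccc1N1CCN(C(=O)CSc2ccc(Cl)cc2Cl)CC1` is the next member, differing from compound 2 by (2,4-dichlorophenyl)sulfanyl in place of 1-((4-chlorophenyl)carbonyl)ethyl on a saturated chain carbon bound to a carbonyl carbon. For the measured compounds named here, the group that leaves carries the carbonyl that compound 2 acquired in the step from compound 1, and the group that enters has none; that step is therefore the only one that bears on the present change, though it is not the same change, since the (2,4-dichlorophenyl)sulfanyl group and the shortened chain have no measured counterpart here. The expectation for compound 3 is a number moving back toward that of compound 1, with the step of a 5.5-fold lower number from compound 2 to compound 3 (0.74 log units; beyond the scatter) estimated as sizeable but uncertain. For compound 3 in this assay the estimate is 200 nM, with a range from 40 nM to 1500 nM.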

Compound 3, inhibition constant: 1500 nM
Beside the measured number, compound 3's estimate is 7.5-fold (0.88 log units) below it; measured number inside the range.
By their numbers in this assay, from the lowest: compound 1; then compounds 2 and 3 (each within the scatter of the next).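

In this assay, putting (2,4-dichlorophenyl)sulfanyl in place of 1-((4-chlorophenyl)carbonyl)ethyl on a saturated chain carbon bound to a carbonyl carbon gives a 1.4-fold higher number from compound 2 to compound 3 (0.13 log units; within the scatter) and so leaves the two side chains indistinguishable on this read-out, although only the group that leaves holds a carbonyl. Absence of a carbonyl from the side chain is therefore not enough to give a number near that of compound 1, as the change of 1-(4-chlorobenzyl)ethyl to ((2,4-dichlorophenyl)sulfanyl)methyl on a carbonyl carbon gives a 48-fold higher number from compound 1 to compound 3 (1.68 log units; beyond the scatter) in the same assay. Nothing available explains either step.

On these data alone, the sulfur, the shorter chain and the second chlorine all change together in compound 3, so the share of each in its distance from compound 1 remains open. A (4-chlorophenyl)sulfanyl group, a (2,4-dichlorophenyl)oxy group or a longer chain ending in 2,4-dichlorophenyl on the same carbon would begin to separate these contributions.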